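Methyl in place of hydroxyquinolinyl on a shared core

The source may hold more compounds than are shown below. What is called first, only, known or untested is meant among the compounds shown, and "the series" means these compounds.

Compound 1 `Cc1nc2c3ccccc3ccc2c2nc3c(ccc4ccccc43)c(-c3ccccc3Cl)c12`: in a functional assay, with a stated time of 90 s (on this read-out lower numbers stand for stronger inhibition and higher numbers for weaker inhibition), compound 1 gives 170 ug/mL.
Compound 2 `Cc1ccc(-c2c3ccc4ccccc4c3nc3c2c(C)nc2c4ccccc4ccc32)cc1`: compound 2 gives 192 ug/mL.
Compound 3 `Cc1nc2c3ccccc3ccc2c2nc3c(ccc4ccccc43)c(-c3cc(O)nc4ccccc34)c12`: compound 3 gives 148 ug/mL.

Compound 3 has the lowest number of the three, yet its steps to both others stay within the scatter: a 1.1-fold lower number from compound 1 to compound 3 (0.06 log units; within the scatter) and a 1.3-fold lower number from compound 2 to compound 3 (0.11 log units; within the scatter). Compound 4 `Cc1nc2c3ccccc3ccc2c2nc3c(ccc4ccccc43)c(C)c12` differs from compound 3 in one place, (methyl in place of 2-hydroxyquinolin-4-yl on an aromatic carbon). Among the measured compounds shown here, the steps that bear on this position, a 1.1-fold higher number from compound 1 to compound 2 (0.05 log units; within the scatter) and the two just named, were all within the scatter, so swapping the aryl group at this carbon changed little; a methyl here is untested. Compound 4 is therefore expected to stay near the measured values, with the step of a 1.4-fold higher number from compound 3 to compound 4 (0.13 log units; within the scatter), and its estimate is 200 ug/mL, range 100 ug/mL to 450 ug/mL.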

Compound 4, half-maximal inhibitory concentration: 195 ug/mL
Beside the measured number, compound 4's estimate is 1.0-fold (0.01 log units) above it; measured number inside the range.
By their numbers in this assay, from the lowest: compounds 3, 1, 2 and 4 (each within the scatter of the next).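

In this assay the aryl group can give way to a lone methyl with no ring: the steps are (a 1.3-fold higher number from compound 3 to compound 4 (0.12 log units; within the scatter)), (a 1.0-fold higher number from compound 2 to compound 4 (0.01 log units; within the scatter)) and (a 1.1-fold higher number from compound 1 to compound 4 (0.06 log units; within the scatter)). On this aromatic carbon, opposite the ring nitrogen, none of the three aryl groups therefore stands apart from methyl, so no ring at this place is shown to be needed. No evidence at hand explains this flat result. The compounds shown leave open whether an amine, a carboxylic acid or a longer chain on this carbon would move the number beyond the scatter.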